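The compounds below may be only part of what the source reports. "The series", "measured", "known", "first", "only" and "open" are said of these compounds alone.

Series notes, values in a functional assay on T47D cells (Homo sapiens) for cytotoxicity, read by sulforhodamine B assay, with a stated time of 48 h; on this read-out lower numbers stand for stronger inhibition of growth and higher numbers for weaker inhibition of growth:

- compound 1 `ClCc1ccccc1Cn1cnc2c(Cl)nc(Cl)nc21`: 5490 nM
- compound 2 `ClCc1cccc(Cn2cnc3ncnc(Cl)c32)c1`: 500 nM
- compound 3 `ClCc1cccc(Cn2cnc3c(Cl)nc(Cl)nc32)c1`: 4460 nM

Compound 2 holds the lowest number of the three in this assay. The nearest is compound 3, whose value lies beyond the scatter above it, and the furthest is compound 1, also beyond the scatter. Within the data shown here, both of those carry two chlorines on the shared core, whereas compound 2 carries one, but each of them also differs from compound 2 elsewhere, so no single step is defined and the values of compounds 1 and 3 stand only as what they are.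

Compound 4 `ClCc1cccc(Cn2cnc3nc(Cl)nc(Cl)c32)c1` is the compound that follows compound 2 by one change: chloro in place of hydrogen on an aromatic carbon. The change is a chloro in place of hydrogen on an aromatic carbon, sitting between two ring nitrogen atoms of the six-membered ring of the fused system.

With no measured step of this kind in the set, the expectation rests on the picture that the two dichloro compounds 1 and 3 give weaker numbers than compound 2 in this assay. A step toward a higher number, beyond the scatter, is expected for compound 4, a 4.0-fold higher number from compound 2 to compound 4 (0.60 log units; beyond the scatter). Compound 4 is estimated at 2000 nM, in the range 600 nM to 6500 nM.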

Compound 4, concentration for total growth inhibition: 610 nM
Compound 4: the middle estimate sits 3.3-fold (0.52 log units) above what was measured; low and high end bracket the measured number.
By their numbers in this assay, from the lowest: compounds 2 and 4 (each within the scatter of the next); then compounds 3 and 1 (each within the scatter of the next).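

In this assay, among these compounds, chloro in place of hydrogen on this aromatic carbon, between two ring nitrogen atoms, gives a 1.2-fold higher number from compound 2 to compound 4 (0.09 log units; within the scatter), the first measured step, and its size cannot be told apart from the scatter of repeated measurements. Among the compounds shown here, this position of the shared core therefore accepts the chloro group with no detectable cost in this read-out, and a second chlorine on the core need not go with a number far from that of compound 2, which the earlier compounds could not show because none of them was linked to compound 2 by a single change. Nothing in the data given here bears on why the chloro group has so little effect at this position.

Still open, as far as these compounds go, is whether this tolerance extends beyond the chloro group, for instance to an amine, a methoxy group or a longer chain at the same carbon. Also open, from the compounds shown here alone, is how the chloromethyl group and the placement of the benzyl substituent contribute when each is varied on its own, with the core held as in compound 4.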